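This account rests on a few compounds, and the source may have more. Where it says the series, first, only, none or still open, it means among the compounds named here.

In an assay on isolated protein for binding affinity to histamine H2 receptor (Homo sapiens) (a higher number here means a weaker inhibitor, a lower number a stronger inhibitor), compound 1 `N#Cc1ccc(-c2ccc(OCCCN3CC[C@H](O)C3)cc2)cc1` gives 19100 nM, and compound 2 `N#Cc1ccc(-c2ccc(OCCCN3CC[C@@H](O)C3)cc2)cc1` gives 17000 nM; the step of a 1.1-fold lower number from compound 1 to compound 2 (0.05 log units; within the scatter) stays within the scatter, which fits (the fact that compounds 1 and 2 differ only in the configuration as drawn). Compound 3 `CCOC(=O)N1CCN(CCCOc2ccc(-c3ccc([N+](=O)[O-])cc3)cc2)CC1` gives 8320 nM, the lowest of the three numbers, beyond the scatter from compound 2 and from compound 1 alike.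

Compound 4 `CCOC(=O)N1CCN(CCCOc2ccc(-c3cccc(C#N)c3)cc2)CC1` differs from compound 3 in one place: 3-cyanophenyl in place of 4-nitrophenyl on an aromatic carbon. Within the data shown here, the only measured step concerns configuration alone and says nothing about exchanging one aromatic substituent for another, so no step beyond the scatter is expected in either direction. Compound 4 is therefore estimated at 8000 nM, with a likely range from 2500 nM to 25000 nM. The expected step is a 1.0-fold lower number from compound 3 to compound 4 (0.02 log units; within the scatter).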

Compound 4, inhibition constant: 24000 nM
For compound 4 the middle estimate is 3.0-fold (0.48 log units) below the measured one; low and high end bracket the measured number.
By their numbers in this assay, from the lowest: compound 3; then compounds 2, 1 and 4 (each within the scatter of the next).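

In this assay, 3-cyanophenyl in place of 4-nitrophenyl gives a 2.9-fold higher number from compound 3 to compound 4 (0.46 log units; beyond the scatter), so this aromatic carbon of the shared core does respond to the group it carries, though only modestly. The earlier pair had shown only that a change of configuration left the number within the scatter, which says nothing about this exchange. No fact given here accounts for the new step.

The exchange alters both the group and its place on the ring, and the compounds shown do not separate those two changes. Where a plain phenyl or 4-methoxyphenyl would fall here also remains open.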